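From 4-bromophenyl to 2,4-dichlorophenyl

A few compounds are considered here, and "the series" means these few. Any claim that something is new, unique, unknown or untested is made for them only; others in the source may bear on it.

For the measured compounds named here, in a functional assay on DU-145 cells (Homo sapiens) for inhibition, read by trypan blue exclusion, with a stated time of 96 h (on this read-out lower numbers stand for stronger inhibition of growth and higher numbers for weaker inhibition of growth), compound 2 `O=C(/C(=C\c1ccc(Br)cc1)S(=O)(=O)c1ccc(Br)cc1)c1ccc(Br)cc1` gives 10000 nM, the lower of the two numbers so far, while compound 1 `O=C(/C(=C\c1ccc(Br)c(O)c1)S(=O)(=O)c1ccc(Br)cc1)c1ccc(Br)cc1` gives 50000 nM. Compound 3 `O=C(/C(=C\c1ccc(Cl)cc1Cl)S(=O)(=O)c1ccc(Br)cc1)c1ccc(Br)cc1` differs from compound 2 as follows: 2,4-dichlorophenyl in place of 4-bromophenyl on a double-bonded chain carbon bound to a double-bonded chain carbon, with 2,4-dichlorophenyl in place of 4-bromophenyl on a double-bonded chain carbon bound to a double-bonded chain carbon. Going by the values given here, the only measured step, a 5.0-fold lower number from compound 1 to compound 2 (0.70 log units; beyond the scatter), was modest and put hydrogen in place of hydroxy on an aromatic carbon, a different change, so it offers weak guidance. No step beyond the scatter is expected, and the estimated step is a 1.3-fold lower number from compound 2 to compound 3 (0.10 log units; within the scatter). For compound 3 the expected value is 8000 nM, with an estimated range of 2500 nM to 30000 nM.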

Compound 3, concentration for 50% growth inhibition: 10000 nM
For compound 3 the middle estimate is 1.3-fold (0.10 log units) below the measured one; low and high end bracket the measured number.
By their numbers in this assay, from the lowest: compounds 2 and 3 (each within the scatter of the next); then compound 1.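

In this assay, the change to 2,4-dichlorophenyl brings no change at the digits printed from compound 2 to compound 3 (within the scatter), so at this position two chlorine atoms serve as well as one bromine. The same ring, set against the 4-bromo-3-hydroxyphenyl of the first compound, brings a 5.0-fold lower number from compound 1 to compound 3 (0.70 log units; beyond the scatter), which leaves the ring with the hydroxy as the only one apart from the other two. No measurement here explains this result. Still open, going by these compounds, is whether an amine or a carboxylic acid on this ring would move the number, and whether an unsubstituted phenyl would hold it.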